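The compounds below may be only part of what the source reports. "The series", "measured", "known", "first", "only" and "open" are said of these compounds alone.

Working notes on the series. All three measured compounds share one core and differ only in the group on an aromatic carbon of the five-membered aromatic ring with 3 nitrogen. Compound 1 `CC(C)(C)c1cn(C[C@H](O)[C@H]2OC(=O)C(OCc3ccccc3)=C2OCc2ccccc2)nn1` gives 13300 nM in an ADME assay on HFF cells (Homo sapiens) for cytotoxicity, read by MTT assay, with a stated time of 72 h; on this read-out higher numbers stand for weaker inhibition and lower numbers for stronger inhibition. Compound 2 `COc1ccccc1-c1cn(C[C@H](O)[C@H]2OC(=O)C(OCc3ccccc3)=C2OCc2ccccc2)nn1` gives 50 nM in this assay. Compound 3 `O=C1O[C@H]([C@@H](O)Cn2cc(-c3ccc(Br)cc3)nn2)C(OCc2ccccc2)=C1OCc1ccccc1` gives 5100 nM in this assay. Compound 3 thus stands second highest of the three numbers: a 2.6-fold lower number from compound 1 to compound 3 (0.42 log units; beyond the scatter), while a 100-fold higher number from compound 2 to compound 3 (2.01 log units; beyond the scatter).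

Compound 4 `O=C1O[C@H]([C@@H](O)Cn2ccnn2)C(OCc2ccccc2)=C1OCc1ccccc1` has not been measured. The change from compound 3 is hydrogen in place of 4-bromophenyl on an aromatic carbon. Among the compounds with values here, no measured step removes the whole group at this carbon; the known steps only exchange one group for another: a 270-fold lower number from compound 1 to compound 2 (2.42 log units; beyond the scatter), a 2.6-fold lower number from compound 1 to compound 3 (0.42 log units; beyond the scatter) and a 100-fold higher number from compound 2 to compound 3 (2.01 log units; beyond the scatter). They show that this position moves the read-out strongly, with 2-methoxyphenyl far lowest and tert-butyl highest, but hydrogen lies outside the range covered. A move toward or past compound 1, that is a higher number, is expected, of modest to large size, with wide uncertainty.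

Compound 4 is estimated at 15000 nM, with a range from 4000 nM to 60000 nM. The expected step is a 2.9-fold higher number from compound 3 to compound 4 (0.47 log units; beyond the scatter).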

Compound 4, half-maximal inhibitory concentration: 610 nM
The estimate for compound 4 lay 25-fold (1.39 log units) above the measured number; measured number below the stated range.
By their numbers in this assay, from the lowest: compound 2; then compound 4; then compound 3; then compound 1.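

In this assay, the bare carbon does not sit at the high end of the series, as the exchanges among substituents left possible, but inside the range they span: an 8.4-fold lower number from compound 3 to compound 4 (0.92 log units; beyond the scatter) and a 22-fold lower number from compound 1 to compound 4 (1.34 log units; beyond the scatter), while a 12-fold higher number from compound 2 to compound 4 (1.09 log units; beyond the scatter). With hydrogen as the reference, the position now reads in two directions: 4-bromophenyl and tert-butyl both go with higher numbers, and only 2-methoxyphenyl goes with a lower one, so a low number needs no group at this carbon, and a phenyl ring as such does not go with a lower number than hydrogen. No measurement bearing on the origin of these differences is available, so the opposite directions of the two aryl groups remain a description only.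

The compounds shown leave open whether the low number of compound 2 belongs to the methoxy group or to the phenyl ring that carries it, since an unsubstituted phenyl at this carbon would separate the two. They also leave open how an amine or a carboxylic acid at this carbon would read against hydrogen, and whether the same order holds on any core other than the shared one.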